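The source may report more compounds than this note shows. Statements on the series, on what has been measured and on what is new or still open speak of the compounds shown alone.

Three compounds have been measured in a functional assay on HeLa cells (Homo sapiens) for antiproliferative activity, with a stated time of 24 h; a lower number here means a stronger inhibitor, a higher number a weaker inhibitor:

Compound 1, `NC(=O)c1c(NC(=O)c2ccccc2Cl)sc2c1CCN(Cc1ccc(Cl)cc1Cl)C2`, gives 21100 nM in this assay.
Compound 2, `NC(=O)c1c(NC(=O)c2ccccc2F)sc2c1CCN(Cc1ccc(Cl)cc1Cl)C2`, gives 27500 nM in this assay.
Compound 3, `NC(=O)c1c(NC(=O)c2ccccc2Cl)sc2c1CCN(C(=S)Nc1cc(C(F)(F)F)cc(C(F)(F)F)c1)C2`, gives 48900 nM in this assay.

Compound 4, `NC(=O)c1c(NC(=O)c2ccccc2F)sc2c1CCN(C(=S)Nc1cc(C(F)(F)F)cc(C(F)(F)F)c1)C2`, has not yet been measured in this assay.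

Compound 4 is related to compound 3 by a single change: fluoro in place of chloro on an aromatic carbon. Exactly the same change, at the same place, links compound 1 to compound 2, where it gave a 1.3-fold higher number from compound 1 to compound 2 (0.12 log units; within the scatter). The change therefore occurs twice among these four compounds, once with a known outcome and once with an outcome still open. Compound 1 and compound 3 carry different cores; the difference between the two cores is not broken down here, and the numbers of compound 1 and compound 3 differ more than the usual scatter allows.

For the measured compounds named here, for compound 4 the expectation rests on the one measured step of this change, the step from compound 1 to compound 2, which stayed within the scatter. Going by the values given here, since the change and its place are identical, the step from compound 3 to compound 4 is estimated to be of a similar small size, about a 1.2-fold higher number from compound 3 to compound 4 (0.09 log units; within the scatter), with the wide range reflecting that only a single earlier example supports it. On that basis compound 4 is expected to give about 60000 nM in this assay, estimated to lie between 30000 nM and 120000 nM.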

Compound 4, half-maximal inhibitory concentration: 28000 nM
The estimate for compound 4 lay 2.1-fold (0.33 log units) above the measured number; the whole stated range lies above it.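

In this assay, replacing the chloro of the 2-chlorophenyl group with fluoro gives a 1.7-fold lower number from compound 3 to compound 4 (0.24 log units; within the scatter). Set beside the same replacement on the core of compound 1, the two steps point in opposite directions on paper, yet both are small and the gap between them is no larger than repeated measurements could produce: the same change on two cores in this assay, a 1.3-fold higher number (0.12 log units; within the scatter) from compound 1 to compound 2 and a 1.7-fold lower number (0.24 log units; within the scatter) from compound 3 to compound 4, 2.3-fold (0.36 log units) apart, within the scatter of two such steps. On both cores, then, the swap from 2-chlorophenyl to 2-fluorophenyl stays within the scatter, which fits the change carrying over from one core to the other, but two small steps show this only for these two cases and cannot reveal whether a slight dependence on the core lies hidden inside the scatter.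

The compounds shown leave open whether other groups in this place, such as a methyl, a methoxy, a nitrile or plain hydrogen, would shift the number further than chloro and fluoro do. They also leave open how the same change would behave on a third core, for example one carrying a plain alkyl chain or a carboxylic acid in place of the groups that set compound 1 and compound 3 apart.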